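This account rests on a few compounds, and the source may have more. Where it says the series, first, only, none or still open, it means among the compounds named here.

Compound 1 `O=C(Nc1ccc(Nc2ncnc3c2cnn3-c2ccccc2)cc1)Nc1cccc(Br)c1`: 36300 nM
Compound 2 `O=C(Nc1ccccc1)Nc1ccc(Oc2ncnc3c2cnn3-c2ccccc2)cc1`: > 100000 nM

Both compounds were tested in a functional assay on MCF7 cells (Homo sapiens) for cytotoxicity, read by sulforhodamine B assay, with a stated time of 72 h; on this read-out lower numbers stand for stronger inhibition and higher numbers for weaker inhibition. Compound 2 reads > 100000 nM, which is a limit of the assay and not a number. Its place on the scale is the limit of > 100000 nM in this assay, at which 1 of the 2 values shown sits, so no exact figure exists for compound 2. Compound 1 gave a true reading of 36300 nM. Among the compounds with values here, compound 1 differs from compound 2 in more than one place, so the pair shows only that one compound gave a number and the other a limit.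

Compound 3 `O=C(Nc1ccccc1)Nc1ccc(Oc2ncnc3c2cnn3-c2ccc(Cl)cc2)cc1` keeps the frame of compound 2 and alters one spot: chloro in place of hydrogen on an aromatic carbon. In words, this is chloro in place of hydrogen on an aromatic carbon, or phenyl to 4-chlorophenyl. Within the data shown here, no measured pair shows what this change does, so the expectation is loose: a modest shift towards stronger inhibition in this assay, or none beyond the scatter, and a second limit would be no surprise. The expected move is an at least 1.4-fold lower number from compound 2 to compound 3 (0.15 log units; that floor lies within the scatter). For compound 3 the estimated value is 70000 nM, with an expected range from 20000 nM to 200000 nM.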

Compound 3, half-maximal inhibitory concentration: 82500 nM
Estimate against measurement, compound 3: 1.2-fold (0.07 log units) below; the measured number falls inside the stated range.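

Compound 3 gives this frame its first true reading in this assay, with the change from phenyl to 4-chlorophenyl on an aromatic carbon, para to a large group. Compound 2 stands at a limit and not at a number, so the change can be given only a floor: the limit of > 100000 nM in this assay, at which 1 of the 3 values shown sits. Read against that limit, the change gives an at least 1.2-fold lower number from compound 2 to compound 3 (0.08 log units; that floor lies within the scatter) and the floor does not clear the usual scatter of repeated measurements, so one chlorine atom at this spot is neither shown to matter nor shown to be without effect, though the frame now has a measured number for later changes to be compared with.

As far as these compounds go, whether a different group at the same spot, such as a methoxy group, an amine or a carboxylic acid, would bring the number clearly down remains open. Also open, from the compounds shown here alone, is whether chloro at this spot would act the same way on the frame of compound 1, which carries a bromine atom on its other end and has its own true reading.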